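The compounds below may be only part of what the source reports. "The series", "measured", "known", "first", "only" and "open" are said of these compounds alone.

Measured compounds in a functional assay on the whole organism (strain Wistar) for inhibition, with Rattus norvegicus as the target, read by paw edema, with stated times of 60 min and 6 h, at a dose of 100 mg/kg by the oral route; on this read-out lower numbers stand for less inhibition and higher numbers for more inhibition at the one dose given (going by the name of the read-out):
compound 1 `CNC(=O)CC1CCc2cc(OC)c(OC)cc21` gives 24.1%
compound 2 `CCN(CC)C(=O)CC1CCc2cc(OC)c(OC)cc21` gives 31.5%
compound 3 `CCCCCNC(=O)CC1CCc2cc(OC)c(OC)cc21` gives 35.2%

Compound 2 stands second highest of the three numbers in this assay. Its nearest neighbour is compound 3, by the step of a number 3.7 percentage points higher from compound 2 to compound 3 (within the scatter), and its furthest is compound 1, by the step of a number 7.4 percentage points higher from compound 1 to compound 2 (within the scatter); neither step separates compound 2 from the other two. For the measured compounds named here, the only step beyond the scatter is a number 11.1 percentage points higher from compound 1 to compound 3 (beyond the scatter), and that one puts butyl in place of hydrogen on a saturated chain carbon bound to an amide-type nitrogen rather than touching the carbonyl carbon itself.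

Compound 4 `COc1cc2c(cc1OC)C(CC(=O)N1CCCC1)CC2` differs from compound 2 in one place: pyrrolidin-1-yl in place of diethylamino on a carbonyl carbon. Going by the values given here, the two measured steps at the carbonyl carbon, a number 7.4 percentage points higher from compound 1 to compound 2 (within the scatter) and a number 3.7 percentage points higher from compound 2 to compound 3 (within the scatter), both stay within the scatter, and no measured pair closes an open amine into a ring, so nothing here speaks for a large move. The step of a number 0.5 percentage points higher from compound 2 to compound 4 (within the scatter) is therefore expected to stay within the scatter, with no fixed direction. Compound 4 is estimated at 32%, with a range from 20% to 44%.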

Compound 4, a percentage reported as inhibition, in the whole organism at one dose (the size of the read-out at that dose, not a potency): 22.2%
For compound 4 the middle estimate is 9.8 percentage points above the measured one; the measured number falls inside the stated range.
By their numbers in this assay, from the lowest: compounds 4, 1, 2 and 3 (each within the scatter of the next, the first and the last beyond it).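

At the carbonyl carbon, pyrrolidin-1-yl brings the first ring to this position in this assay with the same heavy-atom count as diethylamino, and compound 4 stays within the scatter of both neighbours with an open amide group (a number 9.3 percentage points lower from compound 2 to compound 4 (within the scatter); a number 1.9 percentage points lower from compound 1 to compound 4 (within the scatter)). Only the comparison with the pentylamino amide lies beyond the scatter (a number 13 percentage points lower from compound 3 to compound 4 (beyond the scatter)), so closing the ring does not separate compound 4 from diethylamino, while a difference appears against the longer chain. No measurement at hand explains this difference.

From the compounds shown here alone, whether ring size matters at this carbonyl carbon remains open, and piperidin-1-yl or morpholin-4-yl would test that. A cyclopentylamino group would show whether the amide hydrogen or the ring goes with the separation from pentylamino.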